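Trifluoromethyl on the Phenyl Ring: Expected Loss of Potency

The source may report more compounds than this note shows. Statements on the series, on what has been measured and on what is new or still open speak of the compounds shown alone.

Measured so far:
Compound 1 `COc1cc2c(Oc3ccc(NC(=O)c4nnn(-c5ccccc5C)c4C)cc3F)ccnc2cc1OCCCN1CCCC1`: 270 nM
Compound 2 `COc1cc2c(Oc3ccc(NC(=O)c4nnn(-c5ccccc5)c4C)cc3F)ccnc2cc1OCCCN1CCCC1`: 40 nM

In a functional assay on MKN-45 cells (Homo sapiens) for cytotoxicity, read by MTT assay, with a stated time of 72 h (a higher number here means a weaker inhibitor, a lower number a stronger inhibitor), compound 2 gives 40 nM, the lowest of the two numbers measured; its nearest neighbour is compound 1, which gives 270 nM. These two share the same core and differ only at the phenyl ring on the triazole: compound 1 carries a methyl there, compound 2 a hydrogen. That step, a 6.8-fold lower number from compound 1 to compound 2 (0.83 log units; beyond the scatter), shows that removing the methyl made the compound a stronger inhibitor.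

Compound 3 `COc1cc2c(Oc3ccc(NC(=O)c4nnn(-c5ccccc5C(F)(F)F)c4C)cc3F)ccnc2cc1OCCCN1CCCC1` takes the opposite route: trifluoromethyl in place of hydrogen on an aromatic carbon. Going by the values given here, the only step that bears on it is the one from compound 1 to compound 2, where a methyl at the same place cost potency. A trifluoromethyl at that place, larger than a methyl by the count given, is therefore expected to move this assay upward again, by at least as much. The step expected is a 10-fold higher number from compound 2 to compound 3 (1.00 log units; beyond the scatter), weaker than compound 2.

For compound 3 the estimated value is 400 nM, with a likely range from 100 nM to 1600 nM.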

Compound 3, half-maximal inhibitory concentration: 70 nM
The estimate for compound 3 lay 5.7-fold (0.76 log units) above the measured number; measured number below the stated range.
By their numbers in this assay, from the lowest: compounds 2 and 3 (each within the scatter of the next); then compound 1.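

In this assay the new result changes how the earlier methyl step reads: putting trifluoromethyl on this aromatic carbon, ortho to a large group, leaves the number indistinguishable from that of the unsubstituted phenyl ring (a 1.8-fold higher number from compound 2 to compound 3 (0.24 log units; within the scatter)). So the loss seen with methyl is not a general price for having any group at this place, and a group with more heavy atoms than a hydrogen can sit here with no loss that stands out from the scatter. Methyl and trifluoromethyl, which might look like close substitutes on paper, also do not behave alike at this place (a 3.9-fold lower number from compound 1 to compound 3 (0.59 log units; beyond the scatter)), and nothing available here accounts for that difference.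

The compounds shown leave open where other groups would fall, such as a chlorine, a methoxy, an amine or a carboxylic acid on the same carbon: nearer to hydrogen and trifluoromethyl, or nearer to methyl. They also leave open whether trifluoromethyl and methyl would part in the same way on the other carbons of this ring.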